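The compounds below may be only part of what the source reports. "The series", "measured", "known", "first", "only" and "open" are said of these compounds alone.

Three compounds of one series have numbers in an assay on HEK293 cells for displacement of a labelled ligand from NPC1-like intracellular cholesterol transporter 1 (Homo sapiens); on this read-out higher numbers stand for weaker inhibition and lower numbers for stronger inhibition. Compound 1 `O=C(CN1CN(c2ccccc2)C2(CCN(C(=O)c3ccc(C4CCCCC4)cc3)CC2)C1=O)N1CCCCC1` gives 1100 nM. Compound 2 `CS(=O)(=O)NCCNC(=O)CN1CN(c2ccccc2)C2(CCN(C(=O)c3ccc(C4CCCCC4)cc3)CC2)C1=O`, which carries (2-(methanesulfonamido)ethyl)amino in place of piperidin-1-yl on the carbonyl carbon, gives 2100 nM; the step is a 1.9-fold higher number from compound 1 to compound 2 (0.28 log units; within the scatter). Compound 3 `O=C(CN1CN(c2ccccc2)C2(CCN(C(=O)c3ccc(C4CCCCC4)cc3)CC2)C1=O)NCCCCO`, with (4-hydroxybutyl)amino on that carbonyl carbon, gives 10300 nM and so stands at the highest number of the three, separated from the other two by a 9.4-fold higher number from compound 1 to compound 3 (0.97 log units; beyond the scatter) and a 4.9-fold higher number from compound 2 to compound 3 (0.69 log units; beyond the scatter).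

Compound 4 `NCCNC(=O)CN1CN(c2ccccc2)C2(CCN(C(=O)c3ccc(C4CCCCC4)cc3)CC2)C1=O` is not yet measured. Against compound 3 the difference is amino in place of 2-hydroxyethyl on a saturated chain carbon, two bonds along the chain from an amide-type nitrogen. Read one bond further out, 4-hydroxybutyl becomes 2-aminoethyl, so compound 4 shares its chain with compound 2 and differs from compound 2 only in amino in place of methanesulfonamido. The step that bears most directly is a 4.9-fold higher number from compound 2 to compound 3 (0.69 log units; beyond the scatter), which went beyond the scatter when the methanesulfonamido-bearing chain of compound 2 was exchanged for the (4-hydroxybutyl)amino of compound 3. Going the other way, toward the chain of compound 2, the number is expected to fall back toward that of compound 2, though no measured pair shows an amino group, so the size is uncertain. The expected step for compound 4 is a 3.4-fold lower number from compound 3 to compound 4 (0.54 log units; beyond the scatter), a lower number than compound 3. Compound 4 is estimated at 3000 nM, with a range of 1200 nM to 8000 nM.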

Compound 4, half-maximal inhibitory concentration: 3800 nM
For compound 4 the middle estimate is 1.3-fold (0.10 log units) below the measured one, within the range that was stated.
By their numbers in this assay, from the lowest: compounds 1, 2 and 4 (each within the scatter of the next, the first and the last beyond it); then compound 3.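

The free amine keeps the level of the sulfonamide: with hydrogen in place of methylsulfonyl on the amine nitrogen, this assay gives a 1.8-fold higher number from compound 2 to compound 4 (0.26 log units; within the scatter), so the methylsulfonyl group is not needed on this chain to hold that level. The (2-aminoethyl)amino group also recovers part of what the (4-hydroxybutyl)amino group lost, with a 2.7-fold lower number from compound 3 to compound 4 (0.43 log units; beyond the scatter), so compound 3 now stands apart from both compounds that carry the shorter chain, not from compound 2 alone. The amine does not fully match the piperidin-1-yl amide, however, at a 3.5-fold higher number from compound 1 to compound 4 (0.54 log units; beyond the scatter), a separation that compound 2 did not show against compound 1. No measurement here bears on why these numbers differ.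

Compound 3 differs from compound 4 in both chain length and end group, so the compounds shown cannot say which of the two carries the step; a (4-aminobutyl)amino or a (2-hydroxyethyl)amino group on the carbonyl carbon would separate them. Also open, from the compounds shown here alone, is whether a carboxylic acid at the chain end, or a morpholine in place of piperidin-1-yl, would stay at this level.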